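Furan-to-phenyl swap on a shared core

The compounds below may be only part of what the source reports. "The series", "measured", "known", "first", "only" and "open" are said of these compounds alone.

Two hydrazinyl urea compounds have been examined in an assay on isolated protein for binding affinity to sphingosine 1-phosphate receptor 2 (Homo sapiens), read by surface plasmon resonance; a higher number here means weaker binding, a lower number tighter binding. Compound 1, `Cn1nc(C(F)(F)F)c2c(-c3ccccc3)cc(NNC(=O)Nc3cc(Cl)nc(Cl)c3)nc21`, gives 940 nM in this assay. Compound 2, `Cc1nn(C)c2nc(NNC(=O)Nc3cc(Cl)nc(Cl)c3)cc(-c3ccco3)c12`, gives 6520 nM in this assay, the higher of the two numbers and the weaker binding: the number for compound 2 stands well above that of compound 1, and the gap between them lies beyond the scatter of repeated measurements. The two compounds differ in more than one place, so the two values alone do not tell which change carries the gap.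

Compound 3, `Cc1nn(C)c2nc(NNC(=O)Nc3cc(Cl)nc(Cl)c3)cc(-c3ccccc3)c12`, is the next compound and has not yet been measured. It differs from compound 2 in one place: phenyl in place of furan-2-yl on an aromatic carbon. For the measured compounds named here, no measured pair shows this exact change on this core. Compound 1 also carries a phenyl at this position, and it gives 940 nM; this suggests the phenyl may move the number downward. For compound 3 the step from compound 2 is therefore expected to be a 2.6-fold lower number from compound 2 to compound 3 (0.42 log units; beyond the scatter), a moderate tightening of binding. Compound 3 is estimated to give 2500 nM in this assay, with a likely range from 800 nM to 8000 nM.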

Compound 3, dissociation constant: 5320 nM
Compound 3: middle estimate off by 2.1-fold (0.33 log units), on the low side; measured number inside the range.
By their numbers in this assay, from the lowest: compound 1; then compounds 3 and 2 (each within the scatter of the next).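

In this assay, phenyl in place of furan-2-yl on this aromatic carbon gives a 1.2-fold lower number from compound 2 to compound 3 (0.09 log units; within the scatter) on the shared core, so the two rings cannot be told apart at this position, opposite the ring nitrogen, on this core. For the compounds shown here, the one clear step in the new readings lies at the other place, where methyl in place of trifluoromethyl on an aromatic carbon gives a 5.7-fold higher number from compound 1 to compound 3 (0.75 log units; beyond the scatter) and so separates these two groups with only that one place changed. No measurement shown bears on why either step has the size it has.

The compounds shown leave open whether the match of furan-2-yl and phenyl would hold on the core of compound 1, which carries trifluoromethyl, and whether a saturated ring such as cyclohexyl or an amine such as morpholine on the same aromatic carbon would give a reading like those of the two aromatic rings. They also leave open how an ethyl group or a chlorine atom would read in place of the methyl of compound 3.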